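Solubility notes on the shared core: step to naphthyl

The compounds below may be only part of what the source reports. "The series", "measured", "known", "first", "only" and "open" are said of these compounds alone.

Compound 2 `N#Cc1ccc(Cc2ccc3c(NCCCNCc4ccco4)ccnc3c2)cc1` gives 4200 nM in a physicochemical assay for solubility, with a stated time of 18 h, at pH 7.4 (on this read-out lower numbers stand for lower solubility and higher numbers for higher solubility), the lower of the two numbers in hand; compound 1 `COc1ccc(Oc2ccc3c(NCCCNCc4ccco4)ccnc3c2)cc1` gives 14500 nM. Within the data shown here, the single measured step, a 3.5-fold lower number from compound 1 to compound 2 (0.54 log units; beyond the scatter), bears on the next change only loosely, as it exchanged a different pair of groups at the same position. Compound 3 `c1coc(CNCCCNc2ccnc3cc(-c4cccc5ccccc45)ccc23)c1` differs from compound 2 by naphthalen-1-yl in place of 4-cyanobenzyl on an aromatic carbon. Among the measured compounds shown here, with no closer precedent, a further modest downward step is expected, roughly a 2.8-fold lower number from compound 2 to compound 3 (0.45 log units; beyond the scatter). Compound 3 is therefore estimated at 1500 nM, with a range from 400 nM to 5000 nM.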

Compound 3, solubility: 32000 nM
Estimate against measurement, compound 3: 21-fold (1.33 log units) below; measured number outside the range, above it.
By their numbers in this assay, from the lowest: compound 2; then compound 1; then compound 3.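

In this assay naphthalen-1-yl gives a 7.6-fold higher number from compound 2 to compound 3 (0.88 log units; beyond the scatter) and a 2.2-fold higher number from compound 1 to compound 3 (0.34 log units; beyond the scatter) and so puts compound 3 highest of the three. The earlier pair showed only a downward step, whereas this aromatic carbon of the shared core now shows changes in both directions, so no single direction holds for this position. No measured evidence accounts for the rise. Still open, from the compounds shown here alone, is how an amine or a carboxylic acid on this carbon would read in this assay and whether naphthalen-2-yl would match naphthalen-1-yl.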